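The compounds below may be only part of what the source reports. "The series", "measured", "known", "first", "only" and "open" are said of these compounds alone.

Compounds in hand:
compound 1, `Cc1ncnc2c1c(I)cn2[C@@H]1O[C@H](CO)[C@@H](O)[C@H]1O`: 4080 nM in a functional assay on HeLa S3 cells (Homo sapiens) for antiproliferative activity, read by XTT assay, with a stated time of 72 h; a higher number here means a weaker inhibitor, a lower number a stronger inhibitor
compound 2, `C#Cc1cn([C@@H]2O[C@H](CO)[C@@H](O)[C@H]2O)c2ncnc(C)c12`: 14700 nM
compound 3, `Cc1ncnc2c1c(-c1cccs1)cn2[C@@H]1O[C@H](CO)[C@@H](O)[C@H]1O`: the reading is a limit of the assay, > 15000 nM

Among the measured compounds shown here, compound 3 thus stands at the bottom of the series, at the limit of > 15000 nM in this assay, at which 1 of the 3 values shown sits, reached by an at least 3.6-fold higher number from compound 1 to compound 3 (0.56 log units; beyond the scatter) and an at least 1.0-fold higher number from compound 2 to compound 3 (0.00 log units; that floor lies within the scatter), while a 3.6-fold higher number from compound 1 to compound 2 (0.56 log units; beyond the scatter) is the only step between two numbers. Compound 4, `CSc1ncnc2c1c(-c1cccs1)cn2[C@@H]1O[C@H](CO)[C@@H](O)[C@H]1O`, carries methylsulfanyl in place of methyl on an aromatic carbon. None of the three measured steps touches this change; all alter the iodo, ethynyl or thiophen-2-yl group instead, so they give no direction for it. With compound 3 already at the limit, no step beyond the scatter is expected in this assay. Compound 4 is estimated at 20000 nM, range 7000 nM to 60000 nM, that is a step that the limit leaves unreadable from compound 3 to compound 4, most likely again reported only as a limit.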

Compound 4, half-maximal inhibitory concentration: 1960 nM
Compound 4: middle estimate off by 10-fold (1.01 log units), on the high side; measured number below the stated range.
By their numbers in this assay, from the lowest: compound 4; then compound 1; then compound 2. At a limit, above all of these: compound 3.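

In this assay, methylsulfanyl in place of methyl, with the thiophen-2-yl group kept, gives an at least 7.6-fold lower number from compound 3 to compound 4 (0.88 log units; beyond the scatter). Among the compounds shown here, the earlier steps all changed another group, so this is the first sign that the position next to the ring nitrogen affects the reading, and that a thiophen-2-yl compound can give a number. The size of the step remains a floor because compound 3 stands at a limit: the limit of > 15000 nM in this assay, at which 1 of the 4 values shown sits.

As far as these compounds go, whether methylsulfanyl has a similar effect alongside iodo or ethynyl stays open. Also open, from the compounds shown here alone, is how an amine or a longer alkylthio chain would read at this position.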